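Furan in place of dihydrofuran on the amide carbonyl

The source may hold more compounds than are shown below. What is called first, only, known or untested is meant among the compounds shown, and "the series" means these compounds.

Measured compounds and their values:
compound 1, `O=C(Nc1ccc(C(F)(F)F)cc1)NC1CCN(C(=O)C2=COCC2)CC1`, 3.37;
compound 2, `Cc1occc1C(=O)N1CCC(NC(=O)Nc2ccc(OC(F)(F)F)cc2)CC1`, 4.3;
compound 3, `O=C(Nc1ccc(OC(F)(F)F)cc1)NC1CCN(C(=O)C2CCOCC2)CC1`, 3.26.

In a physicochemical assay for lipophilicity, read by HPLC, with a stated time of 90 min, tested at 100 uM (a lower number here means a more polar compound, a higher number a more lipophilic compound), compound 1 gives 3.37, the second highest of the three numbers. Compound 3 sits within the scatter of compound 1, so the two cannot be told apart. Compound 2 stands higher than compound 1 by an amount beyond the scatter. For the measured compounds named here, the only step between compounds that differ in one place is a number 1.04 log units lower from compound 2 to compound 3 (beyond the scatter), and it is a large one.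

Compound 4, `Cc1ccoc1C(=O)N1CCC(NC(=O)Nc2ccc(C(F)(F)F)cc2)CC1`, is not yet measured. It differs from compound 1 by a group of 6 heavy atoms (5 carbon, 1 oxygen; one five-membered aromatic ring with 1 hetero atom) in place of a group of 5 heavy atoms (4 carbon, 1 oxygen; one five-membered non-aromatic ring with 1 hetero atom), on a carbonyl carbon. The step from compound 2 to compound 3 bears on this change in the reverse direction, since there a saturated oxygen ring replaced a methylfuran ring on the same carbonyl carbon and the number fell hard. For compound 4 a rise in this assay beyond the scatter is therefore expected, estimated as a number 0.83 log units higher from compound 1 to compound 4 (beyond the scatter) because a number 1.04 log units lower from compound 2 to compound 3 (beyond the scatter) was itself beyond the scatter. Compound 2, which already carries a methylfuran ring, gives 4.3 and serves as a guide. The estimate for compound 4 is 4.2, expected to fall between 3.8 and 4.6.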

Compound 4, partition coefficient: 4.29
Estimate against measurement, compound 4: 0.09 log units below, within the range that was stated.
By their numbers in this assay, from the lowest: compounds 3 and 1 (each within the scatter of the next); then compounds 4 and 2 (each within the scatter of the next).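

In this assay the position on the carbonyl carbon now moves the number in a second pair, with 3-methylfuran-2-yl replacing the five-membered non-aromatic oxygen ring to give a number 0.92 log units higher from compound 1 to compound 4 (beyond the scatter) on the core of compound 1. Until now this position rested on a single pair, a number 1.04 log units lower from compound 2 to compound 3 (beyond the scatter) in a series with another core, so the new step shows that a large shift is not confined to that pair or to the oxan-4-yl group: in both pairs, the compound with the methylfuran ring has the higher number, and neither pair goes against this. None of the information available explains the size or the direction of the new step.

The single swap changes two things at once, the ring type and the presence of a methyl group, so the compounds shown leave open how much of the step belongs to each. A plain furan-2-yl group on the same carbonyl carbon would separate the two, and a ring with a basic amine, such as piperidin-4-yl, would show how far the number can move in the other direction.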